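The source may hold more compounds than are shown below. What is called first, only, known or untested is meant among the compounds shown, and "the series" means these compounds.

Measured in an in vitro ADME assay on microsomes from liver (Rattus norvegicus) for metabolic stability; on this read-out lower numbers stand for slow clearance and higher numbers for fast clearance:
- Compound 1 `CCC(CC)[C@@H]1C(=O)N[C@H](C2Cc3ccccc3C2)C(=O)N1[C@@H](C(=O)N1CCOCC1)c1ccc(C)nc1`: 1 mL.min-1.g-1
- Compound 2 `Cc1ccc([C@H](C(=O)N(C)C)N2C(=O)[C@@H](C3Cc4ccccc4C3)NC(=O)[C@H]2CC(C)C)cn1`: 3000 mL.min-1.g-1

Compound 2 holds the higher of the two numbers, and the gap to compound 1 lies well beyond the scatter. Compound 3 `CCC(CC)[C@@H]1C(=O)N[C@H](C2Cc3ccccc3C2)C(=O)N1[C@@H](C(=O)N(C)C)c1ccc(C)nc1` departs from compound 2 in one place, with pentan-3-yl in place of isobutyl on a saturated ring carbon. Within the data shown here, no measured pair isolates this change. Compound 1 also carries pentan-3-yl and gives 1 mL.min-1.g-1, although it differs from compound 3 elsewhere, so a drop beyond the scatter is expected in this assay, of uncertain size. The expected step is a 75-fold lower number from compound 2 to compound 3 (1.88 log units; beyond the scatter). The estimated value for compound 3 is 40 mL.min-1.g-1, with a range of 2 mL.min-1.g-1 to 800 mL.min-1.g-1.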

Compound 3, intrinsic clearance in microsomes: 2 mL.min-1.g-1
Estimate against measurement, compound 3: 20-fold (1.30 log units) above, and the stated range covers the measured number.
By their numbers in this assay, from the lowest: compounds 1 and 3 (each within the scatter of the next); then compound 2.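

In this assay, pentan-3-yl in place of isobutyl on the saturated ring carbon now has a measured pair, which gives a 1500-fold lower number from compound 2 to compound 3 (3.18 log units; beyond the scatter) and makes this position highly sensitive to the change in the compounds shown. Dimethylamino in place of morpholin-4-yl on the carbonyl carbon gives a 2.0-fold higher number from compound 1 to compound 3 (0.30 log units; within the scatter) and so cannot be told apart from morpholin-4-yl when pentan-3-yl is present. Still open, as far as these compounds go, is whether isobutyl would keep its high number with morpholin-4-yl on the carbonyl carbon, and how an ethyl chain or a cyclohexyl group would read on this ring carbon. Nothing available explains either step.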